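A few compounds are considered here, and "the series" means these few. Any claim that something is new, unique, unknown or untested is made for them only; others in the source may bear on it.

In an ADME assay on L1210/0 cells (Mus musculus) for cytotoxicity, with a stated time of 48 h (on this read-out higher numbers stand for weaker inhibition and lower numbers for stronger inhibition), compound 1 `Nc1nc(Cl)c2nnn([C@H]3CCCC[C@H]3CO)c2n1` gives 95500 nM, and compound 2 `O=C1OC(C(O)Cn2ccc(=O)[nH]c2=O)C(OCc2ccccc2)=C1OCc1ccccc1` gives 157000 nM. Compound 1 has the lower of the two numbers, yet its gap to compound 2 is within the usual scatter, so the two readings cannot be told apart. Going by the values given here, no pair of measured compounds differs in a single place, so there is no measured step to lean on. Compound 3 `Nc1nc(N)c2nnn([C@H]3CCCC[C@H]3CO)c2n1` has not been measured in this assay. It differs from compound 1 in one place: amino in place of chloro on an aromatic carbon, where chloro leaves and amino enters. With nothing measured on the other side of this change, the expectation for compound 3 rests on compound 1 alone, and the step from compound 1 to compound 3 is expected to be a 1.3-fold higher number from compound 1 to compound 3 (0.10 log units; within the scatter), which is not beyond the scatter. Compound 3 is therefore expected to give about 120000 nM, between 40000 nM and 400000 nM.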

Compound 3, half-maximal inhibitory concentration: > 200000 nM
Compound 3 gave a limit, no number; the forecaster's own chance of this, stated with the estimate: 25%; at least 1.6-fold (0.22 log units) between middle value and limit.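

In this assay, this aromatic carbon next to the ring nitrogen proves sensitive to what it carries: amino in place of chloro gives an at least 2.0-fold higher number from compound 1 to compound 3 (0.32 log units; beyond the scatter). Going by these compounds alone, this is the first step that can be read at a single position, and it shows that, on the core of compound 1, chloro goes with stronger inhibition than amino. Compound 3 stands at a limit of the assay and not at a number, so the full size of the step cannot be read: the limit of > 200000 nM in this assay, at which 1 of the 3 values shown sits.

The compounds shown leave open how a methoxy group, a methyl group or a plain hydrogen on this aromatic carbon would compare with chloro and amino. They also leave open whether amino in place of chloro would have a similar effect with a different chain or ring on the shared core.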